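Cytotoxicity of Two Amides and an Untested Cyclohexyl Analogue

The compounds below may be only part of what the source reports. "The series", "measured", "known", "first", "only" and "open" are said of these compounds alone.

Compound 1 `CC(C)(C)C(=O)N1CCN(c2nc(=O)c3cc(C(F)(F)F)cc([N+](=O)[O-])c3s2)CC1`: > 125000 nM
Compound 2 `CCCC(=O)N1CCN(c2nc(=O)c3cc(C(F)(F)F)cc([N+](=O)[O-])c3s2)CC1`: > 125000 nM

In an ADME assay on Vero cells (Chlorocebus sabaeus) for cytotoxicity, read by MTT assay, with a stated time of 72 h (on this read-out higher numbers stand for lower toxicity in this test and lower numbers for higher toxicity in this test), compound 1 gives > 125000 nM, which is a limit of the assay rather than a number. Compound 2 gives > 125000 nM in this assay, again a limit. The step that the two limits leave unreadable from compound 1 to compound 2 is propyl in place of tert-butyl on a carbonyl carbon, and its size cannot be read because both values sit at the limit of > 125000 nM in this assay, at which 2 of the 2 values shown sit. Compound 1 therefore stands only at a limit in this assay, with no measured number to place it against.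

Compound 3 `CC(C)(C)C1CCC(C(=O)N2CCN(c3nc(=O)c4cc(C(F)(F)F)cc([N+](=O)[O-])c4s3)CC2)CC1` has not yet been measured in this assay. It differs from compound 1 by 4-(tert-butyl)cyclohexyl in place of tert-butyl on a carbonyl carbon. Among the measured compounds shown here, the only measured step that touches the group on the carbonyl carbon is the one between compound 1 and compound 2, and that step is unreadable, so the data give no size of step to carry over. The plainest expectation is that compound 3 also reaches the limit. Compound 3 is estimated at 125000 nM, with a range from 60000 nM to 250000 nM. The step of a number no higher from compound 1 to compound 3 (the limit leaves the size open) is expected to be none beyond the scatter.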

Compound 3, half-maximal cytotoxic concentration: > 125000 nM
Compound 3: only a limit was reported; the forecaster's own chance of this, stated with the estimate: 80%; the middle value lies on the limit itself.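

In this assay compound 3 gives > 125000 nM as a limit of the assay and not a number. Among the compounds shown here, no step among compound 1, compound 2 and compound 3 can be read, as all three stand at the same limit: the limit of > 125000 nM in this assay, at which 3 of the 3 values shown sit. The compounds shown leave open how far each lies from that limit, and whether changing the group on the carbonyl carbon alters the result in this assay at all.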